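The source may hold more compounds than are shown below. What is called first, only, known or untested is meant among the compounds shown, and "the series" means these compounds.

Working notes on the series

Compound 1 `Cc1ccc2c([N+](=O)[O-])cc[n+]([O-])c2c1` is the reference point. In a physicochemical assay for lipophilicity (on this read-out higher numbers stand for higher lipophilicity and lower numbers for lower lipophilicity), compound 1 gives 1.49. Compound 2 `O=[N+]([O-])c1cc[n+]([O-])c2cc(Cl)ccc12` carries the change chloro in place of methyl on an aromatic carbon and in this assay compound 2 gives 1.75; the step is a number 0.26 log units higher from compound 1 to compound 2 (within the scatter).

Compound 3 `Cc1c[n+]([O-])c2ccccc2c1[N+](=O)[O-]` has the same atoms as compound 1 joined differently; how the two cores differ is not broken down here. In this assay compound 3 gives 1.24, the lowest of the three measured values, nearest to compound 1 and furthest from compound 2.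

Compound 4 `O=[N+]([O-])c1c(Cl)c[n+]([O-])c2ccccc12` is not yet measured. It differs from compound 3 by chloro in place of methyl on an aromatic carbon. Among the compounds with values here, this is the same kind of change as the one from compound 1 to compound 2, but the surroundings differ: in compound 1 the place is on a six-membered aromatic ring of carbon only, while in compound 3 it is on a six-membered aromatic ring with one nitrogen, ortho to a nitro group and two atoms from the ring nitrogen.

The step from compound 3 to compound 4 is expected to be a number 0.26 log units higher from compound 3 to compound 4 (within the scatter), resting on the measured step of a number 0.26 log units higher from compound 1 to compound 2 (within the scatter). Compound 4 is therefore estimated at 1.5, between 1.2 and 1.8.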

Compound 4, partition coefficient: 1.33
Compound 4: middle estimate off by 0.17 log units, on the high side, and the stated range covers the measured number.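

In this assay, chloro in place of methyl on an aromatic carbon gives a number 0.09 log units higher from compound 3 to compound 4 (within the scatter) and, on the core of compound 1, gives a number 0.26 log units higher from compound 1 to compound 2 (within the scatter) in the earlier pair; both steps lie within the scatter, and in neither pair does the read-out separate chloro from methyl. Carried from one core to the other, the change therefore stays within the scatter in both surroundings, but two such small steps do not show that the two places respond alike, nor that they respond differently, and two pairs set no rule for the series. No measurement bearing on the reason for either step is available.

The compounds shown leave open what an amine, a carboxylic acid or a longer chain would do in place of methyl on these two cores. They also leave open whether any such group would give a step beyond the scatter on one core, on both, or on neither.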